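Shifting a Hydroxyl Along the Side Chain

The compounds below may be only part of what the source reports. "The series", "measured", "known", "first", "only" and "open" are said of these compounds alone.

Compound 1 `C=C[C@@](C)(O)CC[C@H]1C(=C)CC[C@@H]2[C@]1(C)CCC[C@]2(C)C(=O)O`: in a functional assay on A549 cells (Homo sapiens) for cytotoxicity, read by MTT assay, with a stated time of 48 h (on this read-out lower numbers stand for stronger inhibition and higher numbers for weaker inhibition), compound 1 reaches only the assay limit of > 40000 nM.
Compound 2 `C=CC(=C)CC[C@@H]1[C@@]2(C)CCC[C@](C)(COC(=O)/C=C\c3ccc(O)c(OC)c3)[C@@H]2CC[C@@]1(C)O`: in this assay compound 2 gives 17300 nM.
Compound 3 `C=C1CC[C@@H]2[C@](C)(CCC[C@@]2(C)C(=O)O)[C@H]1CC/C(C)=C/COC(C)=O`: in this assay compound 3 reaches only the assay limit of > 40000 nM.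

Compound 1 therefore has no measured number, only a limit; it shares this standing with one other compound, as the limit of > 40000 nM in this assay, at which 2 of the 3 values shown sit, shows. Compound 4 `C=CC(=C)[C@H](O)C[C@H]1C(=C)CC[C@@H]2[C@]1(C)CCC[C@]2(C)C(=O)O` differs from compound 1 in a single place: a group of 6 heavy atoms (5 carbon, 1 oxygen; no ring) in place of a group of 6 heavy atoms (5 carbon, 1 oxygen; no ring), on a saturated chain carbon bound to a saturated ring carbon. For the measured compounds named here, no pair of measured compounds differs in one place, so no measured step guides the size of this change. Compound 4 is expected to stay close to compound 1, with a step of a number no higher from compound 1 to compound 4 (the limit leaves the size open) that lies within the usual scatter. Compound 4 is therefore estimated at 40000 nM, within a range of 15000 nM to 100000 nM, most likely again reported as a limit.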

Compound 4, half-maximal inhibitory concentration: > 40000 nM
Compound 4 ended at the assay's limit; the forecaster's own chance of this, stated with the estimate: 60%; the middle value sits exactly at the limit.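

Compound 1 and compound 4 both stand at a limit of this assay rather than at a number, so the step between them cannot be read. On these data alone, whether shifting the hydroxyl along the side chain alters cytotoxicity at all stays open.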